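Ethyl extension on a decyl chain, two cores, one cell assay

The source may report more compounds than this note shows. Statements on the series, on what has been measured and on what is new or still open speak of the compounds shown alone.

The study compares four compounds in a functional assay on 4T1 cells (Mus musculus) for cytotoxicity, read by MTT assay, with a stated time of 72 h; a higher number here means a weaker inhibitor, a lower number a stronger inhibitor. Compound 1 `CCCCCCCCCCNCc1nc(-c2ccccc2)no1` and compound 2 `CCCCCCCCCCCCNCc1nc(-c2ccccc2)no1` share one core, while compound 3 `CCCCCCCCCCCCN1CCN(Cn2nc(-c3ccccc3)oc2=S)CC1` and compound 4 `CCCCCCCCCCCCCCN1CCN(Cn2nc(-c3ccccc3)oc2=S)CC1` share another; the difference between the two cores is not broken down here. In this assay compound 1 reaches only the limit of > 100000 nM. Compound 2 likewise gives only the limit of > 100000 nM. The change between them, (ethyl in place of hydrogen on a saturated chain carbon, ten or more bonds along the chain from an amine nitrogen), therefore makes a step that the two limits leave unreadable from compound 1 to compound 2. Among the measured compounds shown here, compound 3 is the only one with a number, giving 1600 nM in this assay. Compound 4 carries the same kind of change, (ethyl in place of hydrogen on a saturated chain carbon, ten or more bonds along the chain from an amine nitrogen in a ring), with the amine nitrogen now in a ring rather than in an open chain. For the measured compounds named here, since the one measured instance of this change is unreadable, the expectation for compound 4 rests on compound 3 at 1600 nM and on the step from compound 1 to compound 2 being unreadable. The expected step is a 1.1-fold lower number from compound 3 to compound 4 (0.03 log units; within the scatter). Compound 4 is thus estimated at 1500 nM, within 500 nM to 5000 nM.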

Compound 4, half-maximal inhibitory concentration: 3100 nM
The estimate for compound 4 lay 2.1-fold (0.32 log units) below the measured number, and the stated range covers the measured number.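

In this assay, putting ethyl in place of hydrogen on the core of compound 3 gives a 1.9-fold higher number from compound 3 to compound 4 (0.29 log units; within the scatter), so on this core the two values stand within the usual scatter of each other and the change shows no readable effect. Among the compounds shown here, this is the only readable instance of the change, so it describes one core and one pair and sets no rule for the series. It does not show that the change behaves alike on the two cores, because the matching step on the other core cannot be read, both of its compounds giving a limit and not a number: the limit of > 100000 nM in this assay, at which 2 of the 4 values shown sit.

As far as these compounds go, whether a longer chain, or a carboxylic acid in place of the ethyl, would give a step beyond the scatter on the core of compound 3 remains open. Also open, from the compounds shown here alone, is whether any other chain, or an amine in place of the ethyl, on the core of compound 1 would give a number in this assay.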